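Trifluoromethyl on the pendant phenyl of compound 1

The compounds below may be only part of what the source reports. "The series", "measured", "known", "first", "only" and "open" are said of these compounds alone.

Measured compounds:
- compound 1, `Cc1nn(-c2nc(-c3ccc(Cl)c(Cl)c3)c(SC(C)C)s2)c(C(=O)O)c1-c1ccccc1`: 3000 nM
- compound 2, `Cc1nn(-c2nc(-c3ccc(Cl)c(Cl)c3)c(SC(C)C)s2)c(C(=O)O)c1-c1cccc(Cl)c1C`: 5100 nM
- compound 3, `Cc1nn(-c2nc(-c3ccc(Cl)c(Cl)c3)c(SC(C)C)s2)c(C(=O)O)c1-c1cnn(C)c1`: 6800 nM

All three share one core and differ only in the aryl group attached to it. In a functional assay on BJAB cells (Homo sapiens) for antiproliferative activity, with a stated time of 4 days (on this read-out lower numbers stand for an effect already at smaller amounts and higher numbers for an effect only at larger amounts of compound), compound 1 gives 3000 nM, the lowest of the three numbers, though only compound 3 lies beyond the scatter from it. Putting 3-chloro-2-methylphenyl in place of phenyl gives a 1.7-fold higher number from compound 1 to compound 2 (0.23 log units; within the scatter). Putting 1-methyl-1H-pyrazol-4-yl in place of phenyl gives a 2.3-fold higher number from compound 1 to compound 3 (0.36 log units; beyond the scatter), a modest step.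

Compound 4, `Cc1nn(-c2nc(-c3ccc(Cl)c(Cl)c3)c(SC(C)C)s2)c(C(=O)O)c1-c1ccccc1C(F)(F)F`, is not yet measured. It differs from compound 1 by trifluoromethyl in place of hydrogen on an aromatic carbon. For the measured compounds named here, the step that bears on it most is the one from compound 1 to compound 2, where a group entering the same ring, also ortho to a large group, stayed within the scatter; the pyrazolyl change in compound 3 was a modest move to higher numbers. A small step, if any, toward higher numbers is therefore expected for compound 4, a 1.3-fold higher number from compound 1 to compound 4 (0.10 log units; within the scatter). The estimate for compound 4 in this assay is 3800 nM, within a range from 1800 nM to 8000 nM.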

Compound 4, half-maximal effective concentration: 5200 nM
Estimate against measurement, compound 4: 1.4-fold (0.14 log units) below; the measured number falls inside the stated range.
By their numbers in this assay, from the lowest: compounds 1, 2, 4 and 3 (each within the scatter of the next, the first and the last beyond it).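

In this assay, trifluoromethyl in place of hydrogen on an aromatic carbon ortho to a large group leaves the number of compound 1 within the scatter (a 1.7-fold higher number from compound 1 to compound 4 (0.24 log units; within the scatter)), so a group of this size is accepted here without a change that this read-out can resolve. The earlier compounds shown here showed this for one substituted phenyl only, and 2-(trifluoromethyl)phenyl now makes a second case, with no difference that can be read against 3-chloro-2-methylphenyl (a 1.0-fold higher number from compound 2 to compound 4 (0.01 log units; within the scatter)) or against 1-methyl-1H-pyrazol-4-yl (a 1.3-fold lower number from compound 3 to compound 4 (0.12 log units; within the scatter)). Nothing measured on these compounds offers a reason for this result.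

On these data alone, all four compounds keep the same shared core and differ only in this aryl group, and none of the new steps goes beyond the scatter, so it remains open whether any group here can move the number clearly in either direction. As far as these compounds go, what a methoxy group or an amine would do in place of the trifluoromethyl stays unknown, as does the effect of trifluoromethyl on another carbon of the phenyl ring.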